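Cyclopropyl for Allyl on the Amide Nitrogen

This account rests on a few compounds, and the source may have more. Where it says the series, first, only, none or still open, it means among the compounds named here.

Three amides built on closely related cores were tested in a toxicity assay on the whole organism (strain Icem-CET (SPF Caw)) for cytotoxicity, with Mus musculus as the target; on this read-out higher numbers stand for an effect only at larger amounts of compound and lower numbers for an effect already at smaller amounts. Compound 1 `C#CCNC(=O)/C(C)=C(\C)c1cc(OC)c(OC)c(OC)c1` gives 150 mg/kg in this assay. Compound 2 `C/C(C(=O)NC1CC1)=C(/C)c1ccc(Br)cc1` gives 130 mg/kg. Compound 3 `C=CCNC(=O)/C(C)=C(/C)c1ccc(OC)cc1` gives 400 mg/kg, the highest of the three numbers, so among these compounds its effect appears only at the largest amounts; its distances to compound 1 and to compound 2 both lie beyond the usual scatter, and of those two compound 1 stands nearer.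

Compound 4 `COc1ccc(/C(C)=C(/C)C(=O)NC2CC2)cc1` has not yet been measured in this assay. It differs from compound 3 in a single place, with the same atoms joined differently: cyclopropyl in place of allyl on an amide-type nitrogen. Compound 2 also carries cyclopropyl on its amide-type nitrogen, yet its aromatic ring carries a different substituent, so its value speaks to the change only indirectly. The move from allyl to cyclopropyl here is therefore expected to lower the number somewhat, and the expected step of a 1.6-fold lower number from compound 3 to compound 4 (0.20 log units; within the scatter) is a moderate one that may or may not clear the scatter. For compound 4 the estimated value in this assay is 250 mg/kg, with a range from 120 mg/kg to 500 mg/kg.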

Compound 4, dose for half-maximal effect: 300 mg/kg
Compound 4: middle estimate off by 1.2-fold (0.08 log units), on the low side, within the range that was stated.
By their numbers in this assay, from the lowest: compounds 2, 1, 4 and 3 (each within the scatter of the next, the first and the last beyond it).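

In this assay, putting cyclopropyl in place of allyl on the amide-type nitrogen, with the rest of the molecule unchanged, comes to a 1.3-fold lower number from compound 3 to compound 4 (0.12 log units; within the scatter), so this read-out does not separate the two compounds. This pair gives the first direct view of the change, and it shows that at this nitrogen the open allyl chain with its double bond and the three-membered carbon ring, built from the same atoms joined differently, give results that cannot be told apart here. No measurement at hand accounts for this result.

The compounds shown leave open how this nitrogen would respond to groups that differ more from these two, such as a longer chain like butyl, or a chain ending in an amine or a carboxylic acid. They also leave open whether the same exchange would again stay within the scatter on a different core, for example with the bromine-bearing ring of compound 2 paired with an allyl group on the nitrogen.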